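Triazole series on the shared core: from compound 3 to compound 4

The source may report more compounds than this note shows. Statements on the series, on what has been measured and on what is new or still open speak of the compounds shown alone.

Compound 1 `Cc1ccc(OCc2cn(-c3ccc(NS(C)(=O)=O)c(Oc4ccccc4)c3)nn2)cc1` gives 13000 nM in a functional assay on HepG2 cells (Homo sapiens) for inhibition, read by MTT assay, with a stated time of 48 h (on this read-out higher numbers stand for weaker inhibition and lower numbers for stronger inhibition), and compound 2 `Cc1cc(OCc2cn(-c3ccc(NS(C)(=O)=O)c(Oc4ccccc4)c3)nn2)ccc1Cl` gives 9800 nM in this assay. Among the compounds with values here, the only measured step, a 1.3-fold lower number from compound 1 to compound 2 (0.12 log units; within the scatter), concerns the group on the oxygen on a saturated carbon and lies within the scatter. Compound 3 `CS(=O)(=O)Nc1ccc(-n2cc(COc3ccc([N+](=O)[O-])cc3)nn2)cc1Oc1ccccc1` gives "not determined" (no result reported) in this assay, so it stands nowhere on the measured scale. Compound 4 `CS(=O)(=O)Nc1ccc(-n2cc(OCc3ccccc3)nn2)cc1Oc1ccccc1` differs from compound 3 as follows: benzyloxy in place of (4-nitrophenoxy)methyl on an aromatic carbon. Within the data shown here, no measured step bears on this change, which sits on the five-membered aromatic ring rather than on the oxygen on a saturated carbon; no direction beyond the scatter can be expected from the data. Compound 4 is estimated at 11000 nM, with a range of 3000 nM to 40000 nM, anchored only on compound 1 and compound 2.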

Compound 4, half-maximal inhibitory concentration: 12300 nM
For compound 4 the middle estimate is 1.1-fold (0.05 log units) below the measured one; low and high end bracket the measured number.
By their numbers in this assay, from the lowest: compounds 2, 4 and 1 (each within the scatter of the next).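

In this assay, benzyloxy on the aromatic carbon of the five-membered ring stands level with both (4-chloro-3-methylphenoxy)methyl and (4-methylphenoxy)methyl, with a 1.3-fold higher number from compound 2 to compound 4 (0.10 log units; within the scatter) and a 1.1-fold lower number from compound 1 to compound 4 (0.02 log units; within the scatter) at this place. The earlier compounds shown here varied only the substituents on the phenyl ring of the arm, whereas these steps exchange the arm itself and still leave the number within the scatter. Compound 3 has no result, so its step to compound 4 cannot be read, and no other measurement bears on this outcome. As far as these compounds go, whether an amine, a carboxylic acid or a longer chain at this place would move the number beyond the scatter remains open.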